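The source may report more compounds than this note shows. Statements on the series, on what has been measured and on what is new or still open speak of the compounds shown alone.

Measured compounds:
- compound 1 `COCOc1cc(/C=C/C(=O)OCC(=O)Nc2ccc(OC)cc2)ccc1OCc1ccccc1`: in a functional assay on HeLa cells (Homo sapiens) for cytotoxicity, read by MTT assay, with a stated time of 72 h (on this read-out lower numbers stand for stronger inhibition and higher numbers for weaker inhibition), compound 1 gives 155000 nM
- compound 2 `COc1ccc(NC(=O)COC(=O)/C=C/c2ccc(OCc3ccccc3)c(O)c2)cc1`: in this assay compound 2 gives > 200000 nM, which is a limit of the assay and not a number

For the measured compounds named here, compound 1 thus stands as the only real number in this small set; the other entry, (the limit of > 200000 nM in this assay, at which 1 of the 2 values shown sits), is a limit and tells only that compound 2 did not reach a measurable value within the tested range. Going by the values given here, the one measured step, an at least 1.2-fold higher number from compound 1 to compound 2 (0.11 log units; that floor lies within the scatter), swaps hydrogen for methoxymethyl on an oxygen on an aromatic ring and sits within the usual scatter.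

Compound 3 `COCOc1cc(/C=C/C(=O)OCC(=O)Nc2nccs2)ccc1OCc1ccccc1` differs from compound 1 elsewhere: 1,3-thiazol-2-yl in place of 4-methoxyphenyl on an amide-type nitrogen. Among the compounds with values here, no measured step touches that amide-type nitrogen, so the only comparison at hand concerns another part of the molecule and gives no direction for this change. On that basis, no step beyond the scatter is expected from compound 1 to compound 3 in this assay, and the estimated step of a 1.0-fold lower number from compound 1 to compound 3 (0.01 log units; within the scatter) reflects that. For compound 3 the expected value in this assay is 150000 nM, with a range from 50000 nM to 450000 nM.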

Compound 3, half-maximal inhibitory concentration: > 200000 nM
Compound 3 was reported as a limit; the forecaster's own chance of this, stated with the estimate: 35%; middle value at least 1.3-fold (0.12 log units) away from the limit.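

The amide-type nitrogen now has its first measured step: in this assay, putting 1,3-thiazol-2-yl in place of 4-methoxyphenyl gives an at least 1.2-fold higher number from compound 1 to compound 3 (0.11 log units; that floor lies within the scatter). The value for compound 3 is a limit of the assay and not a number, so the step cannot separate the two compounds beyond the usual scatter. It does show that this five-membered aromatic ring with 2 hetero atoms gives no lower number at this position, and the set now gathers at one ceiling: the limit of > 200000 nM in this assay, at which 2 of the 3 values shown sit.

What remains open is whether any group on this nitrogen can bring the number clearly down, since only 4-methoxyphenyl and 1,3-thiazol-2-yl are shown there, and a 4-aminophenyl ring, a pyridin-2-yl ring or a plain butyl chain would each test a different kind of group at the same place. Also open is how the 1,3-thiazol-2-yl group behaves with hydrogen in place of methoxymethyl on the aromatic oxygen, a pairing of the two changes that the compounds shown do not include.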